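A Longer Chain on the Way to Compound 3

This account rests on a few compounds, and the source may have more. Where it says the series, first, only, none or still open, it means among the compounds named here.

Of the compounds shown here, two have been measured in a functional assay on the whole organism with Rattus norvegicus as the target, at a dose of 100 mg/kg; on this read-out higher numbers stand for more inhibition at the one dose given (going by the name of the read-out) and lower numbers for less inhibition. Compound 1, with the structure `C/N=C(/NC#N)NCCCCCCn1nc(-c2ccccc2)ccc1=O`, gives 31.7% in this assay. Compound 2, with the structure `C/N=C(\S)NCCCCn1nc(-c2ccccc2)ccc1=O`, gives 87.1% in this assay, the higher of the two numbers, and its distance from compound 1 is beyond the usual scatter. The two differ in more than one place at once, so the numbers say nothing about any single change on its own.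

Compound 3, with the structure `C/N=C(\S)NCCCCCCn1nc(-c2ccccc2)ccc1=O`, is not yet measured. It differs from compound 2 by a group of 7 heavy atoms (4 carbon, 2 nitrogen, 1 sulfur; no ring) in place of a group of 5 heavy atoms (2 carbon, 2 nitrogen, 1 sulfur; no ring), on a saturated chain carbon, four bonds along the chain from an aromatic nitrogen. Compound 2 and compound 3 therefore share everything except the count of chain atoms between the core and the sulfur-bearing end.

Going by the values given here, no measured pair shows a change of this kind by itself. Compound 1, which also carries the longer chain, sits low, but it carries a different end group as well, so its value is only a weak hint. The expectation is a decrease from compound 2 to compound 3 of about a number 25.1 percentage points lower from compound 2 to compound 3 (beyond the scatter), possibly beyond the scatter. Compound 3 is estimated at 62%, with a range from 30% to 92%.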

Compound 3, a percentage reported as inhibition, in the whole organism at one dose (the size of the read-out at that dose, not a potency): 22.2%
Estimate against measurement, compound 3: 39.8 percentage points above; the whole stated range lies above it.
By their numbers in this assay, from the lowest: compounds 3 and 1 (each within the scatter of the next); then compound 2.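

In this assay, compounds 2 and 3 share everything except the change on a saturated chain carbon, four bonds along the chain from an aromatic nitrogen, so this pair shows the effect of that change alone: replacing the group of 5 heavy atoms with the group of 7 heavy atoms gives a number 64.9 percentage points lower from compound 2 to compound 3 (beyond the scatter), a large loss of inhibition at the one dose given. With the longer chain held constant, changing the end group on the amine nitrogen gives a number 9.5 percentage points lower from compound 1 to compound 3 (within the scatter), so in this assay the two end groups cannot be told apart on this chain, and the chain change alone is enough to account for a number as low as that of compound 3. No measurement here explains why the longer chain goes with so much less inhibition.

The compounds shown leave open whether the loss builds gradually or appears suddenly, and whether a shorter or a still longer chain would keep the inhibition of compound 2. They also leave open whether the end group matters on the shorter chain, and how an amine or a carboxylic acid at that end would behave.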